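Swapping (pyridin-2-yl)methyl for cyclobutylmethyl: metabolic stability

The source may hold more compounds than are shown below. What is called first, only, known or untested is meant among the compounds shown, and "the series" means these compounds.

Compound 1 `CS(=O)(=O)Nc1ccc2c(c1)S(=O)(=O)N=C(C1=C(O)C3CCCC3N(Cc3ccccn3)C1=O)N2` in an in vitro ADME assay on microsomes from liver (Homo sapiens) for metabolic stability (a lower number here means that the compound disappears faster, a higher number that the compound lasts longer), gives > 1 h, which is a limit of the assay rather than a number. Compound 2 `CS(=O)(=O)Nc1ccc2c(c1)S(=O)(=O)N=C(C1=C(O)[C@H]3CCC[C@H]3N(CC3CC3)C1=O)N2` in this assay likewise gives > 1 h, again only a limit. Going by the values given here, both values sit at the limit of > 1 h in this assay, at which 2 of the 2 values shown sit, so no measured step between them can be stated. Compound 3 `CS(=O)(=O)Nc1ccc2c(c1)S(=O)(=O)N=C(C1=C(O)C3CCCC3N(CC3CCC3)C1=O)N2` differs from compound 1 by cyclobutyl in place of pyridin-2-yl on a saturated chain carbon bound to an amide-type nitrogen in a ring. With both recorded values at the limit, no step beyond the scatter is expected in this assay for this change. Compound 3 is therefore estimated at 1.3 h, within a range of 0.5 h to 3 h, a step that the limit leaves unreadable from compound 1 to compound 3 that is expected to stay within the scatter.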

Compound 3, half-life: 0.0667 h
Compound 3: middle estimate off by 19-fold (1.29 log units), on the high side; measured number outside the range, below it.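

In this assay, this position proves sensitive: cyclobutyl in place of pyridin-2-yl on a saturated chain carbon bound to an amide-type nitrogen in a ring gives an at least 14-fold lower number from compound 1 to compound 3 (1.17 log units; beyond the scatter). Compound 3 is the only compound shown with a number rather than a limit, and the other two compounds remain at: the limit of > 1 h in this assay, at which 2 of the 3 values shown sit.

Still open, as far as these compounds go, is whether the step follows the loss of pyridin-2-yl or the arrival of cyclobutyl. A benzyl group or a straight butyl chain at this position would help separate the two readings.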